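Oxetan-3-yl in place of isopropylcarbonyl: working notes

A few compounds are considered here, and "the series" means these few. Any claim that something is new, unique, unknown or untested is made for them only; others in the source may bear on it.

Values so far from a functional assay on KARPAS-299 cells (Homo sapiens) for inhibition, read by CellTiter-Glo, with a stated time of 96 h (a lower number here means a stronger inhibitor, a higher number a weaker inhibitor), are these
- compound 1 `Cc1cc(Nc2ncc(Cl)c(Nc3cn(C)nc3S(=O)(=O)C(C)C)n2)c(OC(C)C)cc1C1CCN(C)C1` gives 11 nM
- compound 2 `Cc1cc(Nc2ncc(Cl)c(Nc3cn(C)nc3S(=O)(=O)C(C)C)n2)c(OC2CC2)cc1C(=O)C(C)C` gives "not determined" (no result reported)

Going by these compounds, compound 2 has no number to place it, since the entry for compound 2 reads "not determined" (no result reported) and its standing stays open. The next structure is compound 3 `Cc1cc(Nc2ncc(Cl)c(Nc3cn(C)nc3S(=O)(=O)C(C)C)n2)c(OC2CC2)cc1C1COC1`. The change oxetan-3-yl in place of isopropylcarbonyl on an aromatic carbon puts oxetan-3-yl in place of isopropylcarbonyl on an aromatic carbon. Among the measured compounds shown here, no measured step exists in this assay for this series, so the size and direction of a step from compound 2 cannot be stated. For the measured compounds named here, the only number is compound 1 at 11 nM and it differs from compound 3 in more than one place, so a moderately weaker reading than that value is expected, with wide uncertainty. Compound 3 is expected at 40 nM in an estimated range from 10 nM to 200 nM as a working figure.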

Compound 3, half-maximal inhibitory concentration: 19 nM
Compound 3: the middle estimate sits 2.1-fold (0.32 log units) above what was measured; the measured number falls inside the stated range.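

In this assay, among the compounds shown here, compound 3 gives 19 nM while compound 2 has no number, so no step between compound 2 and compound 3 can be read. The compounds shown leave open how oxetan-3-yl in place of isopropylcarbonyl shifts potency. Nothing available bears on the cause of this result.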